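This account rests on a few compounds, and the source may have more. Where it says the series, first, only, none or still open, it means among the compounds named here.

Of the compounds shown here, three have so far been tested in a functional assay on Hs-578T cells (Homo sapiens) for inhibition, read by sulforhodamine B assay, with a stated time of 48 h, tested at 10 uM; on this read-out higher numbers stand for more inhibition at the one concentration tested (going by the name of the read-out) and lower numbers for less inhibition. Compound 1, `O=Cc1ccc(-c2cn3ccnc3c(-c3ccc4ncn(C5CCCCC5)c4c3)n2)cc1`, gives 45.5% in this assay. Compound 2, `O=Cc1ccc(-c2cn3ccnc3c(-c3ccc4ncn(Cc5ccccc5)c4c3)n2)cc1`, differs from compound 1 only by the change (benzyl in place of cyclohexyl on an aromatic nitrogen), and in this assay compound 2 gives 45.5%. That exchange left the read-out essentially where it was: no change at the digits printed from compound 1 to compound 2 (within the scatter). Compound 3, `c1cn2cc(-c3ccc4c(c3)ncn4C3CCCCC3)nc(-c3ccc4ncn(C5CCCCC5)c4c3)c2n1`, is built on a different core; the difference between the two cores is not broken down here. In this assay compound 3 gives 23.6%, the lowest of the three numbers, and its gap to compound 1 lies beyond the usual scatter.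

Compound 4, `c1ccc(Cn2cnc3ccc(-c4nc(-c5ccc6c(c5)ncn6C5CCCCC5)cn5ccnc45)cc32)cc1`, has not yet been measured in this assay. It arises from compound 3 by benzyl in place of cyclohexyl on an aromatic nitrogen, which is the same change that turned compound 1 into compound 2; the place around the exchanged group is described in exactly the same words in both cases, so this is the same change, occurring twice among these compounds. Since that earlier exchange gave no change at the digits printed from compound 1 to compound 2 (within the scatter), the expectation is that the same swap on the core of compound 3 will again leave the number about where compound 3 stands. Compound 4 is therefore expected to give roughly 24% in this assay, with a plausible range from 10% to 40%. The step this estimate implies is a number 0.4 percentage points higher from compound 3 to compound 4 (within the scatter), an expectation that rests on a single earlier instance of the change, measured on a different core.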

Compound 4, a percentage reported as inhibition, at one concentration (the size of the read-out at that concentration, not a potency): 99.6%
For compound 4 the middle estimate is 75.6 percentage points below the measured one; measured number above the stated range.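

In this assay, benzyl in place of cyclohexyl on an aromatic nitrogen gives a number 76 percentage points higher from compound 3 to compound 4 (beyond the scatter), so an exchange that left the number in place on the core of compound 1 makes a large difference on the core of compound 3, and the two instances clearly disagree: the same change on two cores in this assay, no change at the digits printed (within the scatter) from compound 1 to compound 2 and a number 76 percentage points higher (beyond the scatter) from compound 3 to compound 4, 76 percentage points apart, beyond the scatter of two such steps

This shows that, in this series, the outcome of this exchange on one core is a poor guide to its outcome on the other, so the result of a swap has to be measured on each core rather than assumed. It does not show why the two cores respond so differently, and with only two instances it gives no rule for any further core; each number also comes from a single concentration, so neither step says anything about potency.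

The compounds shown leave open how a methyl group or a longer chain, such as phenylethyl, on that aromatic nitrogen would behave on either core, and so whether benzyl itself matters. Also open, from the compounds shown here alone, is what the same exchange would do at the cyclohexyl that compound 4 still carries.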